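The source may report more compounds than this note shows. Statements on the series, on what has been measured and on what is new or still open speak of the compounds shown alone.

In an ADME assay on a cell-free system (serum) for metabolic stability (a lower number here means that the compound disappears faster, a higher number that the compound lasts longer), three compounds have been measured so far. Compound 1 `CC(C)(C)c1cc(OC(=O)c2ccc(Cl)cc2Cl)ccc1O` gives a half-life of 0.167 h, which is an actual number. Compound 2 `CC(C)(C)c1cc(NC(=O)c2ccc(Cl)cc2Cl)cc(C(C)(C)C)c1O` reads > 1 h, which is a limit of the assay and not a number. Compound 3 `CC(C)(C)c1cc(NC(=O)c2c(Cl)cc(N)cc2Cl)ccc1O` reads > 1 h, which is also a limit. From the compounds shown here alone, compound 3 therefore stands at the limit of > 1 h in this assay, at which 2 of the 3 values shown sit, and its exact half-life remains unknown.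

Compound 4 `CC(C)(C)c1cc(NC(=O)c2c(Cl)cc(N3CCNCC3)cc2Cl)ccc1O` keeps all of compound 3 except for one group, with piperazin-1-yl in place of amino on an aromatic carbon, meta to two chloro groups and para to a large group (piperazin-1-yl in place of amino on an aromatic carbon). No measured pair among these compounds shows what this swap does in this assay, so no firm direction can be expected. The expectation rests on compound 3 alone, whose reading of > 1 h is a limit. The estimated step that the limit leaves unreadable from compound 3 to compound 4 is expected to stay within the usual scatter. A reading that is again only a limit is the more likely outcome. For compound 4 the estimated half-life is 1.5 h, with an expected range from 0.6 h to 4 h.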

Compound 4, half-life: > 1 h
Compound 4 ended at the assay's limit; the forecaster's own chance of this, stated with the estimate: 70%; the middle value lies beyond the limit too.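

Compound 3 and compound 4 both read as a limit of the assay and not as a number, so no step between them can be read: the limit of > 1 h in this assay, at which 3 of the 4 values shown sit.

The compounds shown leave open the actual half-life of compound 3 and of compound 4, and so whether piperazin-1-yl in place of amino changes it at all.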